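The source may report more compounds than this note shows. Statements on the series, on what has been measured and on what is new or still open speak of the compounds shown alone.

Measured so far in a functional assay on SK-BR-3 cells (Homo sapiens) for antiproliferative activity, read by MTT assay, with a stated time of 72 h; a lower number here means a stronger inhibitor, a higher number a weaker inhibitor:
compound 1 `C/C=C1/[C@H](O[C@@H]2O[C@H](COC(C)=O)[C@@H](OC(C)=O)[C@H](OC(C)=O)[C@H]2OC(C)=O)OC=C(C(=O)OC)[C@H]1CC(=O)OCCC`: 6600 nM
compound 2 `C/C=C1/[C@H](O[C@@H]2O[C@H](CO)[C@@H](O)[C@H](O)[C@H]2O)OC=C(C(=O)OC)[C@H]1CC(=O)OCCc1ccc(F)cc1`: > 20000 nM
compound 3 `C/C=C1/[C@H](O[C@@H]2O[C@H](CO)[C@@H](O)[C@H](O)[C@H]2O)OC=C(C(=O)O)[C@H]1CC(=O)OC`: > 20000 nM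

Within the data shown here, compound 1 is the only member of the set with a numerical reading in this assay, at 6600 nM. Compound 2 sits at the limit of this assay, > 20000 nM, and gives no number. Compound 3 also sits at the limit of this assay, > 20000 nM, and gives no number. Compound 1 therefore stands apart from the rest by the limit of > 20000 nM in this assay, at which 2 of the 3 values shown sit. Among the measured compounds shown here, compounds 2 and 3 carry the free sugar, compound 1 the tetraacetylated sugar, but no pair in the set differs in a single place, so no measured step is available to calibrate any change.

The next compound, compound 4 `C/C=C1/[C@H](O[C@@H]2O[C@H](COC(C)=O)[C@@H](OC(C)=O)[C@H](OC(C)=O)[C@H]2OC(C)=O)OC=C(C(=O)OC)[C@H]1CC(=O)OCCCC`, is compound 1 with methyl in place of hydrogen on a saturated chain carbon, three bonds along the chain from an oxygen next to a carbonyl group. This is a homologation of the ester chain, propyl to butyl, with the tetraacetylated sugar and the rest of the core held fixed. With no measured step of this kind in the set, the expectation rests on the change itself: one saturated carbon added to a flexible chain, which is expected to move the reading by no more than the scatter, with no clear direction. Compound 4 is accordingly estimated at 5500 nM, within 2200 nM to 14000 nM, a step of a 1.2-fold lower number from compound 1 to compound 4 (0.08 log units; within the scatter) expected to stay within the scatter.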

Compound 4, half-maximal inhibitory concentration: > 15000 nM
Compound 4: only a limit was reported (the forecaster's own chance of this, stated with the estimate: 10%); at least 2.7-fold (0.43 log units) between middle value and limit.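

Adding one saturated carbon at this position, propyl to butyl on the ester chain with the tetraacetylated sugar and the rest of the core unchanged, is not a silent change in this assay: it gives an at least 2.2-fold higher number from compound 1 to compound 4 (0.35 log units; beyond the scatter). The reading for compound 4 is a limit and not a number: the limit of > 15000 nM in this assay, at which 1 of the 4 values shown sits. Among these compounds, this is the only measured step in the set, and it shows that a methyl in place of hydrogen on a saturated chain carbon, three bonds along the chain from an oxygen next to a carbonyl group, can move the reading beyond the scatter, although the data give no cause for the shift.

One step does not describe how the reading runs along the chain: an ethyl or a hexyl ester on the same tetraacetylated compound would show whether it continues as a trend, and a terminal amine on the chain would test a change other than length. Among the compounds shown here, how the tetraacetylated and free sugars compare also stays open, since no pair in the set differs at the sugar alone.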